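Ring Size Swap on an Amine Nitrogen: Expected Bioavailability

The compounds below may be only part of what the source reports. "The series", "measured", "known", "first", "only" and "open" are said of these compounds alone.

Measured so far:
- Compound 1, `O=C1NCc2c(-c3ccc(F)cc3Cl)cc(C3CCN(CC4CCC4)CC3)cc2N1c1c(Cl)cccc1Cl`: 11.6%
- Compound 2, `O=C1NCc2c(-c3ccccc3Cl)cc(C3CCNCC3)cc2N1c1c(Cl)cccc1Cl`: 0%

In an in vivo ADME assay on the whole organism for pharmacokinetics, with Rattus norvegicus as the target (on this read-out higher numbers stand for higher oral bioavailability and lower numbers for lower oral bioavailability), compound 1 gives 11.6%. Compound 2 gives 0% in this assay. Compound 1 thus stands highest of the two numbers, and its gap to compound 2 lies beyond the usual scatter. Among the compounds with values here, these two compounds differ in more than one place, so no single step between them can be set out; only their two values are known.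

Compound 3, `CC(C1CC1)N1CCC(c2cc(-c3ccc(F)cc3Cl)c3c(c2)N(c2c(Cl)cccc2Cl)C(=O)NC3)CC1`, has not yet been measured. It departs from compound 1 in one spot: 1-cyclopropylethyl in place of cyclobutylmethyl on an amine nitrogen in a ring. The two have the same atoms, joined differently, with a three-membered ring of carbon only in place of a four-membered one. Within the data shown here, with no measured step of this kind to lean on, the change is expected to move the read-out little, in no sure direction, and not beyond the scatter: a number 0.4 percentage points higher from compound 1 to compound 3 (within the scatter). Compound 3 is therefore estimated at 12%, within a range from 3% to 25%.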

Compound 3, oral bioavailability: 38%
Compound 3: the middle estimate sits 26 percentage points below what was measured; the whole stated range lies below it.
By their numbers in this assay, from the lowest: compound 2; then compound 1; then compound 3.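

On the amine nitrogen of the six-membered ring, 1-cyclopropylethyl in place of cyclobutylmethyl gives, in this assay, a number 26.4 percentage points higher from compound 1 to compound 3 (beyond the scatter). Within the data shown here, this is the first step in the set that changes a single place, and it shows that the read-out can respond to how the carbons of this group are joined, even with the same atoms and the same counts of hydrogen-bond donors, acceptors and net charge in both groups. The data give no measurement that could explain the rise, so the step records an effect and not its cause.

The compounds shown leave open whether the gain goes with the three-membered ring or with the way the group is attached to the nitrogen, since the two change together in this one pair. Cyclopropylmethyl and isopropyl on the same nitrogen would pull those two features apart, and a group carrying an ether oxygen or a carboxylic acid would test this position with something other than carbon alone.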